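Side chain on the aromatic nitrogen: from methoxycarbonyl to carboxymethyl

The source may report more compounds than this note shows. Statements on the series, on what has been measured and on what is new or still open speak of the compounds shown alone.

Three compounds with a shared core have numbers in an ADME assay on L929 cells (Mus musculus) for cytotoxicity, read by resazurin assay, with a stated time of 48 h (a higher number here means that more compound is tolerated, a lower number that less compound is tolerated), so far. With vinyl on an aromatic nitrogen, compound 1 `C=Cn1c2ccc([N+](=O)[O-])cc2c(=O)n1Cc1ccccc1` gives 160000 nM. With 3-bromopropyl there, compound 2 `O=c1c2cc([N+](=O)[O-])ccc2n(CCCBr)n1Cc1ccccc1` gives 25200 nM. With (methoxycarbonyl)methyl there, compound 3 `COC(=O)Cn1c2ccc([N+](=O)[O-])cc2c(=O)n1Cc1ccccc1` gives 129000 nM. Compound 3 therefore sits level with compound 1 within the scatter and above compound 2.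

Compound 4 `O=C(O)CCn1c2ccc([N+](=O)[O-])cc2c(=O)n1Cc1ccccc1` alters only this side chain: carboxymethyl in place of methoxycarbonyl on a saturated chain carbon bound to an aromatic nitrogen. In short, carboxymethyl stands in place of methoxycarbonyl on a saturated chain carbon bound to an aromatic nitrogen.

Going by the values given here, no measured compound carries carboxymethyl, so the steps offer only indirect guidance. The change of side chain behind a 1.2-fold lower number from compound 1 to compound 3 (0.09 log units; within the scatter) stays within the scatter. The larger moves, a 6.3-fold lower number from compound 1 to compound 2 (0.80 log units; beyond the scatter) and a 5.1-fold higher number from compound 2 to compound 3 (0.71 log units; beyond the scatter), both involve the bromine-bearing chain of compound 2, which compound 4 lacks. In this assay, no step beyond the scatter is therefore expected, with compound 3 at 129000 nM as the anchor. The estimated step is a 1.1-fold higher number from compound 3 to compound 4 (0.04 log units; within the scatter). Compound 4 is estimated at 140000 nM, with an expected range of 60000 nM to 300000 nM.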

Compound 4, concentration lethal to 50% of the cells: > 256000 nM
Compound 4 ended at the assay's limit (the forecaster's own chance of this, stated with the estimate: 15%); middle value at least 1.8-fold (0.26 log units) away from the limit.
By their numbers in this assay, from the lowest: compound 2; then compounds 3 and 1 (each within the scatter of the next). At a limit, above all of these: compound 4.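

In this assay the result for compound 4 is a limit and not a number: the limit of > 256000 nM in this assay, at which 1 of the 4 values shown sits. The one floor that clears the scatter is an at least 10-fold higher number from compound 2 to compound 4 (1.00 log units; beyond the scatter), so replacing the bromine-bearing chain with 2-carboxyethyl on the aromatic nitrogen leaves the low number of compound 2 behind, and this position now holds a free carboxy end as well as an ester and a vinyl group. The other two readings are an at least 1.9-fold higher number from compound 3 to compound 4 (0.29 log units; that floor lies within the scatter) and an at least 1.6-fold higher number from compound 1 to compound 4 (0.20 log units; that floor lies within the scatter); both floors lie within the scatter, so the exchange of the (methoxycarbonyl)methyl chain for 2-carboxyethyl, and of vinyl for 2-carboxyethyl, can so far be read only as no loss in this assay, with any real gain unproven.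

From the compounds shown here alone, how far the true number of compound 4 lies past the limit remains open, and with it whether the steps to compound 3 and compound 1 are real. Also open, going by these compounds, is whether a longer chain ending in a carboxylic acid, or a chain ending in an amine, would reach the same limit at this position on the shared core.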